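Swapping Cyclopropylsulfonyl for Fluorophenylsulfonyl on a Shared Core

The source may report more compounds than this note shows. Statements on the series, on what has been measured and on what is new or still open speak of the compounds shown alone.

Among the compounds with values here, compound 1 `CCN(CC)c1ccc2cc(C(=O)c3ccc(N4CCN(C(=O)CN5CCN(S(=O)(=O)C6CC6)CC5)CC4)cc3)oc2c1` gives 17300 nM in a functional assay on A549 cells (Homo sapiens) for cytotoxicity, read by MTT assay, with a stated time of 48 h (on this read-out higher numbers stand for weaker inhibition and lower numbers for stronger inhibition), and among the three measured compounds it is the only one that returns a number rather than a limit. Compound 2 `CCN(CC)c1ccc2cc(C(=O)c3ccc(N4CCN(C(=O)CN5CCN(S(=O)(=O)c6ccc(C(F)(F)F)cc6)CC5)CC4)cc3)oc2c1` carries 4-(trifluoromethyl)phenyl on the sulfonyl sulfur where compound 1 has cyclopropyl. In this assay compound 2 gives > 40000 nM, which is a limit of the assay. Compound 3 `CCN(CC)c1ccc2cc(C(=O)c3ccc(N4CCN(C(=O)CN5CCN(S(=O)(=O)c6ccc(C#N)cc6)CC5)CC4)cc3)oc2c1` carries 4-cyanophenyl on the sulfonyl sulfur. In this assay compound 3 gives > 40000 nM, again a limit. The measured steps read an at least 2.3-fold higher number from compound 1 to compound 2 (0.36 log units; beyond the scatter) and an at least 2.3-fold higher number from compound 1 to compound 3 (0.36 log units; beyond the scatter), while between compound 2 and compound 3 there is a step that the two limits leave unreadable from compound 2 to compound 3. Compound 4 `CCN(CC)c1ccc2cc(C(=O)c3ccc(N4CCN(C(=O)CN5CCN(S(=O)(=O)c6ccc(F)cc6)CC5)CC4)cc3)oc2c1` differs from compound 1 by 4-fluorophenyl in place of cyclopropyl on a sulfonyl sulfur. Both measured replacements of cyclopropyl by a substituted phenyl on the sulfonyl sulfur pushed the read-out to the limit of > 40000 nM in this assay, at which 2 of the 3 values shown sit, so a weakening is expected for compound 4 as well, of a size that may again reach the limit. Compound 4 is therefore expected to give about 40000 nM in this assay, with a range from 15000 nM to 100000 nM. The expected step is a 2.3-fold higher number from compound 1 to compound 4 (0.36 log units; beyond the scatter).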

Compound 4, half-maximal inhibitory concentration: 33200 nM
Estimate against measurement, compound 4: 1.2-fold (0.08 log units) above; measured number inside the range.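

In this assay, 4-fluorophenyl on the sulfonyl sulfur is the one substituted phenyl group shown that returns a number rather than a limit, and the change reads a 1.9-fold higher number from compound 1 to compound 4 (0.28 log units; within the scatter), so putting a phenyl ring in place of cyclopropyl at this position does not by itself separate a compound from compound 1. Against the other two phenyl compounds, the change is only bounded, reading an at least 1.2-fold lower number from compound 3 to compound 4 (0.08 log units; that floor lies within the scatter) and an at least 1.2-fold lower number from compound 2 to compound 4 (0.08 log units; that floor lies within the scatter); neither floor clears the scatter, the step between compound 2 and compound 3 cannot be read, and fluoro therefore cannot be ranked against cyano or trifluoromethyl. The upper end of the read-out still restricts what this small set can show: the limit of > 40000 nM in this assay, at which 2 of the 4 values shown sit.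

The compounds shown leave open how an unsubstituted phenyl ring, or a phenyl ring carrying a methoxy group or an amine, would read at this position. They also leave open whether any group on the sulfonyl sulfur, such as a longer alkyl chain like n-butyl, would give a number clearly lower than that of compound 1.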